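The source may report more compounds than this note shows. Statements on the series, on what has been measured and on what is new or still open speak of the compounds shown alone.

Compound 1, `CN(C)c1nc(N)nc2c1ncn2/C=C1/CC1(CO)CO`, in an ADME assay on BCBL1 cells (Homo sapiens) for cytotoxicity, with a stated time of 7 days (a higher number here means that more compound is tolerated, a lower number that less compound is tolerated), gives > 20000 nM, which is a limit of the assay rather than a number.
Compound 2, `CCCNc1nc(N)nc2c1ncn2/C=C1/CC1(CO)CO`, in this assay gives > 20000 nM, again a limit.
Compound 3, `Nc1nc(NC2CCCCC2)c2ncn(/C=C3/CC3(CO)CO)c2n1`, in this assay gives > 20000 nM, also a limit.

All three measured compounds share one core and differ only in the group on one aromatic carbon. Within the data shown here, compound 1 therefore has no definite place on the scale: its value is a limit, as are those of compound 2 and compound 3, so every value so far sits on the same line, (the limit of > 20000 nM in this assay, at which 3 of the 3 values shown sit). The steps between them cannot be read: a step that the two limits leave unreadable from compound 1 to compound 2, a step that the two limits leave unreadable from compound 1 to compound 3 and a step that the two limits leave unreadable from compound 2 to compound 3 each run from one limit to another, leaving their size unknown.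

Compound 4, `CCCCCCOc1nc(N)nc2c1ncn2/C=C1/CC1(CO)CO`, is not yet measured. It differs from compound 1 by hexyloxy in place of dimethylamino on an aromatic carbon. Among the measured compounds shown here, the three measured steps bear on this change only as the nearest exchanges at the same carbon, and since each was unreadable they give no size and no direction for the step to compound 4. The plain expectation is that compound 4 again reaches the limit, so the expected step is a step that the limit leaves unreadable from compound 1 to compound 4. Compound 4 is therefore estimated at 30000 nM, with a range from 12000 nM to 100000 nM, most likely reported only as a limit.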

Compound 4, half-maximal cytotoxic concentration: > 20000 nM
Compound 4: no number, only a limit (the forecaster's own chance of this, stated with the estimate: 80%); the middle value does not contradict the limit.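

From the compounds shown here alone, no new step can be read: the steps from compound 1, compound 2 and compound 3 to compound 4 all run from one limit to another, so their sizes stay unknown, and all four results stand at the same point: the limit of > 20000 nM in this assay, at which 4 of the 4 values shown sit. The compounds shown leave open whether exchanging the group on this aromatic carbon changes how much compound the cells tolerate, and in which direction.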